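Mirror-image configuration of a cyclohexane sulfonamide amide

A few compounds are considered here, and "the series" means these few. Any claim that something is new, unique, unknown or untested is made for them only; others in the source may bear on it.

Measured so far:
compound 1, `CC(=O)N[C@H]1CC[C@@H](NS(=O)(=O)c2ccc(F)cc2)CC1`: 10 mg/kg
compound 2, `CCC(=O)N[C@H]1CC[C@H](NS(=O)(=O)c2ccc(F)cc2)CC1`: 0.1 mg/kg

Of the compounds shown here, two have been tested in a functional assay on the whole organism with Mus musculus as the target, with a stated time of 20 min; on this read-out lower numbers stand for an effect already at smaller amounts and higher numbers for an effect only at larger amounts of compound. Compound 1, `CC(=O)N[C@H]1CC[C@@H](NS(=O)(=O)c2ccc(F)cc2)CC1`, gives 10 mg/kg in this assay. Compound 2, `CCC(=O)N[C@H]1CC[C@H](NS(=O)(=O)c2ccc(F)cc2)CC1`, gives 0.1 mg/kg and so stands at the lowest number of the two; the gap to compound 1 lies well beyond the scatter, though compound 1 differs from compound 2 both in the amide chain and in the drawn configuration, so the two changes cannot be separated on these numbers alone.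

Compound 3, `CCC(=O)N[C@H]1CC[C@@H](NS(=O)(=O)c2ccc(F)cc2)CC1`, has not yet been measured. Its difference from compound 2 is the two compounds have the same atoms and bonds and differ only in configuration as drawn: 2 of 2 stereo elements differ (all stereocentres are inverted: mirror images); a stereocentre at a saturated ring carbon is drawn r in compound 2 and s in compound 3; a stereocentre at a saturated ring carbon is drawn r in compound 2 and s in compound 3. Going by the values given here, no pair of measured compounds differing only in configuration exists here, so there is no direct precedent for the size of the step. Since nothing leaves and nothing enters, compound 3 is expected to stay close to compound 2, with a step of a 2.0-fold higher number from compound 2 to compound 3 (0.30 log units; within the scatter) that is expected to lie within or only slightly beyond the scatter. Compound 3 is therefore estimated at 0.2 mg/kg, with a range from 0.05 mg/kg to 1 mg/kg.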

Compound 3, minimum effective dose: 10 mg/kg
Estimate against measurement, compound 3: 50-fold (1.70 log units) below; the measured number lies above the stated range.
By their numbers in this assay, from the lowest: compound 2; then compounds 1 and 3 (each within the scatter of the next).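

In this assay the drawn configuration alone carries a large effect, with a 100-fold higher number from compound 2 to compound 3 (2.00 log units; beyond the scatter). That gap can be set down to configuration and to nothing else, because no atom or bond changes: the fact that compounds 2 and 3 differ only in the configuration as drawn. Within the configuration shared by compound 1 and compound 3, the other change, methyl in place of hydrogen on a saturated chain carbon bound to a carbonyl carbon, shows no change at the digits printed from compound 1 to compound 3 (within the scatter), so in this configuration the longer amide chain brings no visible change, and the two changes that could not be separated before now come apart at least this far.

Going by these compounds, what stays open is whether the amide chain counts for as little in the configuration of compound 2, since the step for that chain is known only in the configuration of compound 3. On these data alone, it is also open how far the low number of compound 2 would survive a longer chain on the amide carbonyl, or an amine or a nitrile in place of the fluorine on the sulfonamide side.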